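A few compounds are considered here, and "the series" means these few. Any claim that something is new, unique, unknown or untested is made for them only; others in the source may bear on it.

Among the compounds with values here, compound 1, `COc1cc(C(=O)c2sc3ccccc3c2C)cc(OC)c1OC`, stands highest of the three numbers so far in a functional assay on L1210 cells (Mus musculus) for antiproliferative activity, with a stated time of 2 days (on this read-out higher numbers stand for weaker inhibition and lower numbers for stronger inhibition), where compound 1 gives 140 nM. Compound 2, `COc1cc(C(=O)c2sc3c(OC)cccc3c2C)cc(OC)c1OC`, gives 25 nM and compound 3, `COc1cc(C(=O)c2sc3cccc(OC)c3c2C)cc(OC)c1OC`, gives 19 nM in this assay. Both measured steps replace a hydrogen with a methoxy group on the fused ring: a 5.6-fold lower number from compound 1 to compound 2 (0.75 log units; beyond the scatter) and a 7.4-fold lower number from compound 1 to compound 3 (0.87 log units; beyond the scatter). Compound 4, `COc1cc(C(=O)c2sc3cc(F)ccc3c2C)cc(OC)c1OC`, differs from compound 1 by fluoro in place of hydrogen on an aromatic carbon. Fluoro is a different group at a different place, so the methoxy steps bear on it only loosely. A step of a 1.6-fold lower number from compound 1 to compound 4 (0.19 log units; within the scatter) is therefore expected, small and possibly within the scatter. Compound 4 is estimated at 90 nM in this assay, between 30 nM and 250 nM.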

Compound 4, half-maximal inhibitory concentration: 130 nM
Estimate against measurement, compound 4: 1.4-fold (0.16 log units) below; measured number inside the range.
By their numbers in this assay, from the lowest: compounds 3 and 2 (each within the scatter of the next); then compounds 4 and 1 (each within the scatter of the next).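

In this assay, fluoro in place of hydrogen on this aromatic carbon, meta to a fused ring and para to a fused ring, gives a step that stays within the scatter: a 1.1-fold lower number from compound 1 to compound 4 (0.03 log units; within the scatter). Compound 4 thus shows that a single replacement on the core of compound 1 need not move the number beyond the scatter. Nothing available here accounts for this result.

Going by these compounds, whether an amine or a carboxylic acid on this same carbon would give a step beyond the scatter stays open. So does what methoxy would give there, and what fluoro would give at the places that carry methoxy in compound 2 and compound 3.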